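Carbamoyl in place of cyano in a cytotoxicity series

A few compounds are considered here, and "the series" means these few. Any claim that something is new, unique, unknown or untested is made for them only; others in the source may bear on it.

Of the compounds shown here, three have been tested in a functional assay on KB cells (Homo sapiens) for cytotoxicity; a higher number here means a weaker inhibitor, a lower number a stronger inhibitor. Compound 1 `NC(=S)c1cn(COCc2ccccc2)c2ncnc(N)c12` reaches only a limit of the assay, giving > 100000 nM. Compound 2 `COCCOCn1cc(C#N)c2c(N)ncnc21` likewise returns a limit, > 100000 nM. Compound 3 `Cc1ccccc1Cn1cc(C#N)c2c(N)ncnc21` also gives a limit, > 100000 nM. Compound 2 therefore stands with the limit of > 100000 nM in this assay, at which 3 of the 3 values shown sit, and no number ranks it against the other two. Compound 4 `COCCOCn1cc(C(N)=O)c2c(N)ncnc21` is the next case, differing from compound 2 by carbamoyl in place of cyano on an aromatic carbon. Going by the values given here, no measured step in the set gives a precedent for this change. With every known value at the limit, the expected step in this assay is a number no higher from compound 2 to compound 4 (the limit leaves the size open), none beyond the scatter. Compound 4 is estimated at 100000 nM in this assay, within 30000 nM to 300000 nM, most likely reported again as a limit.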

Compound 4, half-maximal inhibitory concentration: > 100000 nM
Compound 4 ended at the assay's limit (the forecaster's own chance of this, stated with the estimate: 85%); the middle value lies on the limit itself.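

Compound 2 and compound 4 both sit at the assay's limit, so no step can be read for carbamoyl in place of cyano. The compounds shown leave open whether any structure in this series gives a measurable value in this assay.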